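A few compounds are considered here, and "the series" means these few. Any claim that something is new, unique, unknown or untested is made for them only; others in the source may bear on it.

Compound 1 `CCCn1c(=O)[nH]c2nc(-c3ccc(S(=O)(=O)N4CCN(c5cccc(Br)c5)CC4)cc3)[nH]c2c1=O`: 27%
Compound 2 `CCCn1c(=O)[nH]c2nc(-c3ccc(S(=O)(=O)N4CCN(c5ccccc5F)CC4)cc3)[nH]c2c1=O`: 9%
Compound 3 `CCCn1c(=O)[nH]c2nc(-c3ccc(S(=O)(=O)N4CCN(c5ccc(C)cc5)CC4)cc3)[nH]c2c1=O`: 25%

These three compounds share one core and were tested in an assay on CHO cells for displacement of a labelled ligand from adenosine receptor A3 (Homo sapiens), read by scintillation counting, with a stated time of 45 min, tested at 1 uM, in the presence of a further agent that is not named here; on this read-out lower numbers stand for less inhibition and higher numbers for more inhibition at the one concentration tested (going by the name of the read-out). Compound 3 stands second highest of the three numbers: its gap to compound 1, a number 2 percentage points lower from compound 1 to compound 3 (within the scatter), is within the scatter, so those two cannot be told apart, whereas the gap a number 16 percentage points higher from compound 2 to compound 3 (beyond the scatter) lies beyond the scatter.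

Compound 4 `CCCn1c(=O)[nH]c2nc(-c3ccc(S(=O)(=O)N4CCN(c5ccccc5Cl)CC4)cc3)[nH]c2c1=O` is not yet measured. It differs from compound 3 in one place: 2-chlorophenyl in place of 4-methylphenyl on an amine nitrogen in a ring. For the measured compounds named here, two measured steps bear on this change. The step of a number 16 percentage points higher from compound 2 to compound 3 (beyond the scatter) shows that going from a 2-fluorophenyl to a 4-methylphenyl raised the number modestly, and the step of a number 18 percentage points lower from compound 1 to compound 2 (beyond the scatter) shows that arriving at the 2-fluorophenyl lowered it modestly. A 2-chlorophenyl resembles the 2-fluorophenyl in where the halogen sits, so a modest drop is expected. Compound 4 is expected to give 13%, in the range 4% to 24%, which means an expected step of a number 12 percentage points lower from compound 3 to compound 4 (beyond the scatter).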

Compound 4, a percentage reported as inhibition, at one concentration (the size of the read-out at that concentration, not a potency): 32%
Beside the measured number, compound 4's estimate is 19 percentage points below it, outside the stated range (above it).
By their numbers in this assay, from the lowest: compound 2; then compounds 3, 1 and 4 (each within the scatter of the next).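

Changing fluoro to chloro on the aromatic carbon gives a number 23 percentage points higher from compound 2 to compound 4 (beyond the scatter) in this assay, so a halogen on the 2-position of this phenyl ring does not by itself keep the number low: the identity of the halogen matters here. The other two steps, a number 7 percentage points higher from compound 3 to compound 4 (within the scatter) and a number 5 percentage points higher from compound 1 to compound 4 (within the scatter), are both within the scatter, so the 2-chlorophenyl, 4-methylphenyl and 3-bromophenyl groups cannot be told apart, and only compound 2, with its 2-fluorophenyl group, stands clearly lower. No measurement available here accounts for the gap between the fluoro and chloro compounds.

On these data alone, whether the low number is specific to fluoro remains open, as does the effect of a methoxy group or a nitrile on this phenyl ring. With a single concentration tested, these numbers also leave the potency of all four compounds unknown.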